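Methoxycarbonyl to carbamoyl: expected stability of compound 3

This account rests on a few compounds, and the source may have more. Where it says the series, first, only, none or still open, it means among the compounds named here.

In an ADME assay (liver) for metabolic stability, with Liver microsome (Homo sapiens) as the target, read by LC-MS, using microsomes and NADPH, with a stated time of 1 h, tested at 1 uM (a lower number here means that less of the compound is left, a higher number that more of the compound is left), compound 1 (`O=C(O)c1cnc(Oc2ccc3c(c2)B(O)OC3)cn1`) has the entry "not determined" (no result reported), so it provides no number. Among the compounds with values here, compound 2 (`COC(=O)c1cnc(Oc2ccc3c(c2)B(O)OC3)cn1`) gives 0%, the only number, so no ranking among measured compounds is possible. Compound 3 (`NC(=O)c1cnc(Oc2ccc3c(c2)B(O)OC3)cn1`) keeps the shared core and has amino in place of methoxy on a carbonyl carbon. Within the data shown here, no measured pair shows what this exchange does, so the expectation is uncertain. Because compound 2 gives 0%, any change beyond the scatter in this assay can only be upward. A large upward step is expected, and the estimated step is a number 60 percentage points higher from compound 2 to compound 3 (beyond the scatter). For compound 3, the estimated value is 60%, with an expected range of 25% to 95%.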

Compound 3, percent of the compound remaining: 87%
The estimate for compound 3 lay 27 percentage points below the measured number; measured number inside the range.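

In this assay, methoxy gives way to amino on a carbonyl carbon, and this single exchange, also readable as methoxycarbonyl to carbamoyl, comes with a number 87 percentage points higher from compound 2 to compound 3 (beyond the scatter). Within the data shown here, it is the first measured step, and it shows that the read-out is highly sensitive to the group on this carbonyl carbon: with the shared core unchanged, the pair runs from no compound left to most of it left. No measurement at hand bears on the reason for this step.

One exchange does not show whether amino is special here or whether other groups on the same carbonyl carbon would serve as well. As far as these compounds go, a methylamino or dimethylamino group, or a longer ester chain such as ethoxy, would stand in the same place, and what these would give remains open.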